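Chloro for isopropyl in a rapidly cleared series

The source may report more compounds than this note shows. Statements on the series, on what has been measured and on what is new or still open speak of the compounds shown alone.

Measured in an ADME assay on microsomes from liver (Mus musculus) for metabolic stability, read by LC-MS, using NADPH, tested at 1 uM; a higher number here means faster removal of the compound, a lower number slower removal:
compound 1 `Cc1cnc(NC(=O)CCCOc2cccc(Cl)n2)s1`: > 866 mL.min-1.g-1 (a limit)
compound 2 `CC(C)c1cnc(NC(=O)CCCOc2ccccc2)s1`: 740 mL.min-1.g-1
compound 3 `Cc1cnc(NC(=O)NCCOc2ccc(Cl)c(C)c2)s1`: > 866 mL.min-1.g-1 (a limit)

Among the compounds with values here, compound 2 carries the only true number in this assay, at 740 mL.min-1.g-1. The other two readings are limits and not numbers: the limit of > 866 mL.min-1.g-1 in this assay, at which 2 of the 3 values shown sit. Within the data shown here, no two measured compounds differ in one place only, so the series offers no direct step to lean on, and their values can only be set side by side.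

The next compound to be read is compound 4 `O=C(CCCOc1ccccc1)Nc1ncc(Cl)s1`. Its difference from compound 2 is chloro in place of isopropyl on an aromatic carbon. With compound 2 at 740 mL.min-1.g-1 and no reading in the series resolved at a low number, clearance is expected to stay high. The expected change is a 1.6-fold lower number from compound 2 to compound 4 (0.22 log units; within the scatter), a modest fall that stays within the usual scatter, and its direction is only tentative. The estimate for compound 4 is 450 mL.min-1.g-1, with an expected range from 180 mL.min-1.g-1 to 860 mL.min-1.g-1.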

Compound 4, intrinsic clearance in microsomes: 814 mL.min-1.g-1
Compound 4: middle estimate off by 1.8-fold (0.26 log units), on the low side; the measured number falls inside the stated range.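

Within the data shown here, the first step in one place in this assay reads a 1.1-fold higher number from compound 2 to compound 4 (0.04 log units; within the scatter) and lies within the scatter. At this position next to the ring sulfur, chloro in place of isopropyl therefore leaves clearance unchanged within the scatter, with one heavy atom entering where three leave, and the 5-position swap gives no route out of the high range on this evidence alone. Compound 1 and compound 3 still give limits and not numbers, so this step cannot be carried over to them: the limit of > 866 mL.min-1.g-1 in this assay, at which 2 of the 4 values shown sit.

Open, going by these compounds, is whether an amine or a carboxylic acid at this position, or a longer chain elsewhere on the shared core, would bring the number down beyond the scatter. Also open, on these data alone, is how far the step carries to compound 1, whose reading is a limit.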